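Two cores, one change: a sulfonyl substitution revisited

A few compounds are considered here, and "the series" means these few. Any claim that something is new, unique, unknown or untested is made for them only; others in the source may bear on it.

Measured compounds:
compound 1 `O=C(NCCCCl)Nc1cccc(S(=O)(=O)Oc2ccc(O)cc2)c1` gives 51000 nM
compound 2 `O=C(NCCCCl)Nc1ccc(S(=O)(=O)Oc2ccc(O)cc2)cc1` gives 50000 nM
compound 3 `Cc1ccccc1NS(=O)(=O)c1cccc(NC(=O)NCCCCl)c1` gives 42000 nM

All three were tested in a functional assay on HT-29 cells (Homo sapiens) for cytotoxicity, read by sulforhodamine B assay, with a stated time of 48 h; on this read-out higher numbers stand for weaker inhibition and lower numbers for stronger inhibition. Compound 1 and compound 2 have the same atoms joined differently, and the difference between the two cores is not broken down here; their values lie within the scatter of each other. Compound 3 differs from compound 1 in one place: (2-methylphenyl)amino in place of 4-hydroxyphenoxy on a sulfonyl sulfur. That step, a 1.2-fold lower number from compound 1 to compound 3 (0.08 log units; within the scatter), is within the scatter, so the change did not move the read-out in a recognisable way.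

Compound 4 `Cc1ccccc1NS(=O)(=O)c1ccc(NC(=O)NCCCCl)cc1`, not yet measured, carries the same change applied to the core of compound 2: (2-methylphenyl)amino in place of 4-hydroxyphenoxy on a sulfonyl sulfur. The place is described in the same words for both pairs, so the change is of the same kind on a different core.

Because the earlier step was a 1.2-fold lower number from compound 1 to compound 3 (0.08 log units; within the scatter), compound 4 is expected to sit close to compound 2, with an estimated step of a 1.2-fold lower number from compound 2 to compound 4 (0.08 log units; within the scatter). On that basis compound 4 is estimated at 42000 nM in this assay, with a likely range from 20000 nM to 90000 nM.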

Compound 4, half-maximal inhibitory concentration: 64000 nM
Estimate against measurement, compound 4: 1.5-fold (0.18 log units) below; the range from low to high includes it.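

In this assay, (2-methylphenyl)amino in place of 4-hydroxyphenoxy on a sulfonyl sulfur gave a 1.3-fold higher number from compound 2 to compound 4 (0.11 log units; within the scatter), so this change did not move the read-out in a recognisable way on the core of compound 2 either. Set side by side, the steps on the two cores cannot be told apart: the same change on two cores in this assay, a 1.2-fold lower number (0.08 log units; within the scatter) from compound 1 to compound 3 and a 1.3-fold higher number (0.11 log units; within the scatter) from compound 2 to compound 4, 1.6-fold (0.19 log units) apart, within the scatter of two such steps. This shows that the change behaved alike within the resolution of the assay on these two cores, but it does not show that the two steps are identical, and with neither step beyond the scatter it does not show how a change with a clear effect would carry from one core to the other.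

The compounds shown leave open whether a different group on the sulfonyl sulfur, such as a morpholine or a carboxylic acid, would shift the read-out on either core. They also leave open what a longer chain in place of the chlorine-bearing chain would do.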